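Swapping the nitrophenyl urea arm for a sulfur-bearing chlorophenyl group

This account rests on a few compounds, and the source may have more. Where it says the series, first, only, none or still open, it means among the compounds named here.

In an assay for binding affinity to Apoptosis regulator Bcl-2 (Homo sapiens), read by fluorescence polarization, with stated times of 30 min and 20 min, tested at 100 uM (a higher number here means more inhibition at the concentration tested (going by the name of the read-out), a lower number less inhibition), compound 1 `O=C(Nc1cccc([N+](=O)[O-])c1)N1CCN(S(=O)(=O)c2sccc2-c2ccccc2Oc2ccc(O)c(O)c2)CC1` gives 30%, the highest of the three numbers shown; compound 2 `COc1ccc(Oc2ccccc2-c2ccsc2S(=O)(=O)N2CCN(C(=O)Nc3cccc([N+](=O)[O-])c3)CC2)cc1OC` gives 18% and compound 3 `COc1ccc(Oc2ccccc2-c2ccsc2S(=O)(=O)N2CCN(C(=O)Nc3ccc([N+](=O)[O-])cc3)CC2)cc1OC` gives 17%. Among the compounds with values here, the only change of the catechol, a number 12 percentage points lower from compound 1 to compound 2 (beyond the scatter), and the only move of the nitro group, a number 1 percentage points lower from compound 2 to compound 3 (within the scatter), both sit elsewhere than the change now considered. Compound 4 `O=S(=O)(c1sccc1-c1ccccc1Oc1ccc(O)c(O)c1)N1CCN(C(=S)Nc2ccc(Cl)cc2)CC1` differs from compound 1 in this way: a group of 10 heavy atoms (7 carbon, 1 nitrogen, 1 sulfur, 1 chlorine; one six-membered aromatic ring of carbon only) in place of a group of 12 heavy atoms (7 carbon, 2 nitrogen, 3 oxygen; one six-membered aromatic ring of carbon only), on an amine nitrogen in a ring. Within the data shown here, no measured step touches the arm that is exchanged here, so no direction can be read from the data. Compound 4 is therefore expected to give about 25% in this assay, between 8% and 45%, an expected change of a number 5 percentage points lower from compound 1 to compound 4 (within the scatter).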

Compound 4, a percentage reported as inhibition, at one concentration (the size of the read-out at that concentration, not a potency): 2%
Estimate against measurement, compound 4: 23 percentage points above; measured number outside the range, below it.
By their numbers in this assay, from the lowest: compound 4; then compounds 3 and 2 (each within the scatter of the next); then compound 1.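

In this assay the arm on the ring nitrogen proves sensitive: exchanging the (3-nitrophenyl)carbamoyl group gives a number 28 percentage points lower from compound 1 to compound 4 (beyond the scatter) with the catechol kept, while moving the nitro group gave only a number 1 percentage points lower from compound 2 to compound 3 (within the scatter) in the dimethoxy series. No measurement shown here explains this loss. The exchange alters several things at once, bringing in sulfur and chlorine and removing the nitro group, so the compounds shown cannot say which of these changes carries the loss. Going by these compounds, how an arm ending in an amine or a carboxylic acid would behave also remains open.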